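The compounds below may be only part of what the source reports. "The series", "measured", "known", "first", "only" and "open" are said of these compounds alone.

Measured compounds in a functional assay on MKN-45 cells (Homo sapiens) for cytotoxicity, read by MTT assay, with a stated time of 72 h; a higher number here means a weaker inhibitor, a lower number a stronger inhibitor:
Compound 1 `CN(C)CCn1cnnc1-c1cc(Oc2ccc(NC(=O)N/N=C/c3ccc(Cl)cc3Cl)cc2F)ccn1` gives 750 nM.
Compound 2 `COc1ccc(/C=N/NC(=O)Nc2ccc(Oc3ccnc(-c4nncn4CCN(C)C)c3)c(F)c2)c(OC)c1OC` gives 2020 nM.
Compound 3 `CN(C)CCn1cnnc1-c1cc(Oc2ccc(NC(=O)N/N=C/c3ccc(Cl)cc3)cc2F)ccn1` gives 570 nM.

Compound 3 has the lowest number of the three; one gap is a 1.3-fold lower number from compound 1 to compound 3 (0.12 log units; within the scatter), the other gap is a 3.5-fold lower number from compound 2 to compound 3 (0.55 log units; beyond the scatter).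

Compound 4 `COc1cc(/C=N/NC(=O)Nc2ccc(Oc3ccnc(-c4nncn4CCN(C)C)c3)c(F)c2)ccc1O` differs from compound 3 in one place: 4-hydroxy-3-methoxyphenyl in place of 4-chlorophenyl on a carbon with a double bond to nitrogen. Among the compounds with values here, the one step that bears on it is the exchange of an oxygenated aryl for a chloroaryl on the same carbon, a 3.5-fold lower number from compound 2 to compound 3 (0.55 log units; beyond the scatter); the 1>2 step is the same exchange seen from the other side. Moving back to an oxygenated aryl is therefore expected to raise the number by a modest amount in this assay, roughly a 2.5-fold higher number from compound 3 to compound 4 (0.39 log units; beyond the scatter). Compound 4 is expected to give about 1400 nM, within 600 nM to 3500 nM.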

Compound 4, half-maximal inhibitory concentration: 3780 nM
Compound 4: middle estimate off by 2.7-fold (0.43 log units), on the low side; measured number outside the range, above it.
By their numbers in this assay, from the lowest: compounds 3 and 1 (each within the scatter of the next); then compounds 2 and 4 (each within the scatter of the next).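

In (this assay), the exchange on the carbon with a double bond to nitrogen costs more with 4-hydroxy-3-methoxyphenyl than the earlier oxygenated aryl indicated (a 6.6-fold higher number from compound 3 to compound 4 (0.82 log units; beyond the scatter); a 5.0-fold higher number from compound 1 to compound 4 (0.70 log units; beyond the scatter)). Against the other oxygenated aryl (a 1.9-fold higher number from compound 2 to compound 4 (0.27 log units; within the scatter)), the gap stays within the scatter, so the two oxygenated aryl groups cannot be told apart here and both stand apart from the 4-chlorophenyl of compound 3. No measurement on hand accounts for this gap. Open, going by these compounds, is whether an aryl bearing an amine or a carboxylic acid would fall with the chloroaryl compounds or with compound 2 and compound 4.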